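Swapping the Aryl Group on a Shared Quinoline-Free Core

This account rests on a few compounds, and the source may have more. Where it says the series, first, only, none or still open, it means among the compounds named here.

Measured so far:
- compound 1, `COc1ccc(F)cc1CNCCCNc1ccnc2cc(Cc3ccc(F)cc3)ccc12`: 23 10^-6 cm/s
- compound 2, `COc1ccc(F)cc1CNCCCNc1ccnc2cc(-c3cccc4ccccc34)ccc12`: 237 10^-6 cm/s

Compound 1 and compound 2 share a core and differ only in the group on one aromatic carbon. In an ADME assay for permeability, using PAMPA, with a stated time of 30 min, at pH 7.4 (a lower number here means that the compound crosses the layer more slowly, a higher number that the compound crosses the layer faster), compound 1 gives 23 10^-6 cm/s, while compound 2 gives 237 10^-6 cm/s, which is the higher of the two numbers; the step of a 10-fold higher number from compound 1 to compound 2 (1.01 log units; beyond the scatter) is large and beyond the usual scatter.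

Compound 3, `COc1ccc(-c2ccc3c(NCCCNCc4cc(F)ccc4OC)ccnc3c2)cc1`, is not yet measured. It differs from compound 2 at the same aromatic carbon: 4-methoxyphenyl in place of naphthalen-1-yl on an aromatic carbon

Among the compounds with values here, only the step from compound 1 to compound 2 bears on this, and only indirectly, since it shows that changing the group at this carbon can move the permeability a great deal. Compound 3 is therefore expected to land below compound 2, with a 2.6-fold lower number from compound 2 to compound 3 (0.42 log units; beyond the scatter), giving an estimate for compound 3 of 90 10^-6 cm/s within 30 10^-6 cm/s to 250 10^-6 cm/s.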

Compound 3, apparent permeability: 237 10^-6 cm/s
Beside the measured number, compound 3's estimate is 2.6-fold (0.42 log units) below it; low and high end bracket the measured number.
By their numbers in this assay, from the lowest: compound 1; then compounds 2 and 3 (each within the scatter of the next).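

In this assay, replacing naphthalen-1-yl, with its two six-membered aromatic rings, by 4-methoxyphenyl, with one such ring and a hydrogen-bond acceptor, gives no change at the digits printed from compound 2 to compound 3 (within the scatter), so this carbon tolerates this particular swap without any shift that can be told from the scatter. The large rise seen earlier is also not unique to naphthalen-1-yl, since putting 4-methoxyphenyl in place of 4-fluorobenzyl gives a 10-fold higher number from compound 1 to compound 3 (1.01 log units; beyond the scatter), and the two aryl groups therefore stand equally far from the benzyl group of compound 1. No supporting measurement is available to explain either result.

All three groups shown here are built around a carbon-only aromatic ring, so it remains open how an amine or a carboxylic acid at this carbon would behave. A longer chain carrying the aromatic ring is equally untested by these compounds.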